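Removing a Methyl from an Alaninate-Type Side Chain

A few compounds are considered here, and "the series" means these few. Any claim that something is new, unique, unknown or untested is made for them only; others in the source may bear on it.

Of the compounds shown here, three have been measured in a functional assay on the whole organism (Tail, strain ICR) with Mus musculus as the target, in the tail flick test, with a stated time of 30 min, at a dose of 25 umol/kg by the oral route; on this read-out lower numbers stand for a weaker effect and higher numbers for a stronger effect at the one dose given. Compound 1 `C[C@H](NC(=O)CN(c1nc(Cl)nc2[nH]cnc12)C1CC1)C(=O)OCc1ccccc1` gives 41.2%. Compound 2 `O=C(CN(c1nc(Cl)nc2[nH]cnc12)C1CC1)NCC(=O)OCc1ccccc1` gives 18.7%. The change between them is hydrogen in place of methyl on a saturated chain carbon bound to an amide-type nitrogen and a carbonyl carbon, and it produced a number 22.5 percentage points lower from compound 1 to compound 2 (beyond the scatter). Compound 3 `C[C@@H](O)[C@H](NC(=O)CN(c1ncnc2c1ncn2C1CCCCO1)C1CC1)C(=O)OCc1ccccc1` gives 23.6% in this assay; its value and that of compound 2 lie within the scatter of each other, while compound 1 stands above it. The difference between the core of compound 3 and the core of compound 1 is not broken down here. Compound 4 `O=C(CN(c1ncnc2c1ncn2C1CCCCO1)C1CC1)N[C@@H](CO)C(=O)OCc1ccccc1` is not yet measured. It differs from compound 3 by hydrogen in place of methyl on a saturated chain carbon bound to an oxygen on a saturated carbon and a saturated chain carbon, which is the same kind of change as that from compound 1 to compound 2, though the place differs: there the carbon is bound to an amide-type nitrogen and a carbonyl carbon, here to an oxygen on a saturated carbon and a saturated chain carbon. Because the earlier step gave a number 22.5 percentage points lower from compound 1 to compound 2 (beyond the scatter), compound 4 is expected to sit below compound 3 in this assay, a step estimated as a number 11.6 percentage points lower from compound 3 to compound 4 (beyond the scatter). The estimate for compound 4 is 12%, within 2% to 28%.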

Compound 4, a percentage reported as activity, at one dose (the size of the read-out at that dose, not a potency): 27.8%
Beside the measured number, compound 4's estimate is 15.8 percentage points below it; measured number inside the range.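

In this assay the exchange of methyl for hydrogen did not repeat its earlier result, since this time the step is a number 4.2 percentage points higher from compound 3 to compound 4 (within the scatter). Set beside the earlier step, the two outcomes differ: the same change on two cores in this assay, a number 22.5 percentage points lower (beyond the scatter) from compound 1 to compound 2 and a number 4.2 percentage points higher (within the scatter) from compound 3 to compound 4, 26.7 percentage points apart, beyond the scatter of two such steps. This shows that the loss seen on the core of compound 1 did not carry over to the core of compound 3, but it does not show that the core alone decides the outcome, as the place of the change differs too: a carbon bound to an amide-type nitrogen and a carbonyl carbon in one step, and a carbon bound to an oxygen on a saturated carbon and a saturated chain carbon in the other.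

The compounds shown leave open how the 1-hydroxyethyl to hydroxymethyl change would behave on the core of compound 1. They also leave open what a longer chain or an amine would give in place of the methyl on that saturated chain carbon.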